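The compounds below may be only part of what the source reports. "The series", "measured", "known", "first", "only" and "open" are said of these compounds alone.

In a functional assay on MCF7 cells (Homo sapiens) for antiproliferative activity, read by MTT assay (on this read-out lower numbers stand for stronger inhibition and higher numbers for weaker inhibition), compound 1 (`CCCC/C=C\CCCCCCCCCc1cc(=O)c2c(O)cc(O)c(C)c2o1`) gives 17500 nM. Compound 2 (`CCCCC1(O)CC(=O)c2c(O)cc(O)cc2O1`) gives > 67200 nM, which is a limit and not a number. Compound 3 (`CCCCCCCCCCCCCCCCCCCC1(O)CC(=O)c2c(O)cc(O)cc2O1`) gives > 67200 nM, which is also only a limit. The next compound to be measured is compound 4 (`CCCCCCCCCCCC1(O)CC(=O)c2c(O)cc(O)cc2O1`), and its difference from compound 3 is hydrogen in place of octyl on a saturated chain carbon, ten or more bonds along the chain from a saturated ring carbon. The same difference reads undecyl to propyl when cut one bond further out. Compound 2 and compound 3 both sit at the limit of > 67200 nM in this assay, at which 2 of the 3 values shown sit, which gives no reason to expect a large move in this assay. The expected step, an at least 1.1-fold lower number from compound 3 to compound 4 (0.04 log units; that floor lies within the scatter), stays within the usual scatter. For compound 4 the estimated value is 60000 nM, with an expected range of 25000 nM to 120000 nM.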

Compound 4, half-maximal inhibitory concentration: 43200 nM
The estimate for compound 4 lay 1.4-fold (0.14 log units) above the measured number, within the range that was stated.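

In this assay, hydrogen in place of octyl on the chain yields a measured number where only a limit stood, giving an at least 1.5-fold lower number from compound 3 to compound 4 (0.19 log units; that floor lies within the scatter). Heptyl in place of hydrogen on the chain of compound 2 points the same way, giving an at least 1.5-fold lower number from compound 2 to compound 4 (0.19 log units; that floor lies within the scatter), so the chain of compound 4 is the only one of these three to give a number. Compound 2 and compound 3 remain limits, not numbers: the limit of > 67200 nM in this assay, at which 2 of the 4 values shown sit. As far as these compounds go, the true size of either step stays open, as does whether an amine or a carboxylic acid on the chain of compound 4 would shift the number in this assay.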